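Benzyl substituent variation on a shared nucleoside core

The source may hold more compounds than are shown below. What is called first, only, known or untested is meant among the compounds shown, and "the series" means these compounds.

Measured in a functional assay on HOS cells (Homo sapiens) for antiproliferative activity, with a stated time of 72 h; a higher number here means a weaker inhibitor, a lower number a stronger inhibitor:
compound 1 `OC[C@H]1O[C@@H](n2cnc3c(NCc4cccc(F)c4)ncnc32)[C@H](O)[C@@H]1O` — > 166000 nM, a limit of the assay.
compound 2 `OC[C@H]1O[C@@H](n2cnc3c(NCc4ccc(F)cc4)ncnc32)[C@H](O)[C@@H]1O` — 13200 nM.
compound 3 `OC[C@H]1O[C@@H](n2cnc3c(NCc4ccccc4Br)ncnc32)[C@H](O)[C@@H]1O` — > 166000 nM, a limit of the assay.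

Compound 1 stands at the limit of > 166000 nM in this assay, at which 2 of the 3 values shown sit, so only an upper bound is known for it. Compound 4 `OC[C@H]1O[C@@H](n2cnc3c(NCc4ccc(Cl)c(Cl)c4)ncnc32)[C@H](O)[C@@H]1O` is not yet measured; it differs from compound 1 by 3,4-dichlorophenyl in place of 3-fluorophenyl on a saturated chain carbon bound to a nitrogen on an aromatic ring. For the measured compounds named here, the one readable step from compound 1 is an at least 12-fold lower number from compound 1 to compound 2 (1.09 log units; beyond the scatter), showing that moving the halogen to the 4-position brings the number below the limit. The step that the two limits leave unreadable from compound 1 to compound 3 gives no size. Compound 4 keeps a 4-halogen, so a step of similar direction is expected, an at least 8.3-fold lower number from compound 1 to compound 4 (0.91 log units; beyond the scatter), and compound 4 is estimated at 20000 nM (range 5000 nM to 166000 nM).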

Compound 4, half-maximal inhibitory concentration: > 166000 nM
Compound 4: no number, only a limit; the forecaster's own chance of this, stated with the estimate: 30%; middle value at least 8.3-fold (0.91 log units) away from the limit.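

In this assay the 3,4-dichlorophenyl group does not keep the readable number of the 4-fluorophenyl group, the step being an at least 12-fold higher number from compound 2 to compound 4 (1.09 log units; beyond the scatter). For the compounds shown here, compound 2 therefore remains the only compound here with a number, while 3,4-dichlorophenyl joins 3-fluorophenyl and 2-bromophenyl at the same limit: the limit of > 166000 nM in this assay, at which 3 of the 4 values shown sit. The steps to compound 4 from compound 1 and from compound 3 cannot be read, since both ends are limits.

Going by these compounds, whether a 4-chlorophenyl group alone would keep a number like that of compound 2 stays open, which leaves the effect of the added chlorine unseparated. How far compound 1, compound 3 and compound 4 lie past the limit is also unknown.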